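The source may hold more compounds than are shown below. What is called first, only, known or untested is meant among the compounds shown, and "the series" means these compounds.

Compound 1 `COc1cc(-c2nn(-c3ccc(NC(=O)Nc4ccc(Cl)c(Cl)c4)cc3)cc2-c2ccncc2)ccc1Cl` gives 2840 nM in a functional assay on SK-MEL-5 cells (Homo sapiens) for antiproliferative activity, read by sulforhodamine B assay, with a stated time of 48 h; on this read-out higher numbers stand for weaker inhibition and lower numbers for stronger inhibition. Compound 2 `COc1cc(-c2nn(-c3ccc(NC(=O)Nc4ccc(Cl)c(C(F)(F)F)c4)cc3)cc2-c2ccncc2)ccc1Cl` gives 1570 nM in this assay. Compound 3 `COc1cc(-c2nn(-c3ccc(NC(=O)Nc4cc(C(F)(F)F)cc(C(F)(F)F)c4)cc3)cc2-c2ccncc2)ccc1Cl` gives 1530 nM in this assay.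

Among these three numbers compound 2 stands second highest; its nearest neighbour is compound 3 and its furthest compound 1, and both gaps fall within the scatter, so the three compounds cannot be told apart on this read-out. Going by the values given here, the only measured step, a 1.8-fold lower number from compound 1 to compound 2 (0.26 log units; within the scatter), also stays within the scatter. Compound 4 `COc1cc(-c2nn(-c3ccc(NC(=O)c4ccc(Cl)c(Cl)c4)cc3)cc2-c2ccncc2)ccc1Cl` differs from compound 2 by 3,4-dichlorophenyl in place of (4-chloro-3-(trifluoromethyl)phenyl)amino on a carbonyl carbon. Among the compounds with values here, no measured step touches this part of the molecule, so there is no direct guide to its effect. Absent such a guide, no step beyond the scatter is expected in this assay, but the uncertainty is wide. Compound 4 is estimated at 3000 nM, between 800 nM and 12000 nM, which means an expected step of a 1.9-fold higher number from compound 2 to compound 4 (0.28 log units; within the scatter).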

Compound 4, half-maximal inhibitory concentration: 1650 nM
The estimate for compound 4 lay 1.8-fold (0.26 log units) above the measured number; the range from low to high includes it.
By their numbers in this assay, from the lowest: compounds 3, 2, 4 and 1 (each within the scatter of the next).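

Taking away the amino nitrogen and its hydrogen-bond donor, so that 3,4-dichlorophenyl sits directly on the carbonyl carbon, leaves the read-out in this assay within the scatter (a 1.7-fold lower number from compound 1 to compound 4 (0.24 log units; within the scatter)). The same holds when (4-chloro-3-(trifluoromethyl)phenyl)amino is replaced (a 1.1-fold higher number from compound 2 to compound 4 (0.02 log units; within the scatter)), so at this position the amino link makes no readable difference for these compounds. Nothing measured here offers an explanation for this result. Still open, on these data alone, is whether the carbonyl carbon would give similar numbers with an aliphatic amine such as morpholine in place of the aromatic ring.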